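Ethynyl for benzofuranyl: working notes on the series

The source may hold more compounds than are shown below. What is called first, only, known or untested is meant among the compounds shown, and "the series" means these compounds.

Measured in a functional assay on K562 cells (Homo sapiens), read by MTT assay, with a stated time of 72 h; on this read-out lower numbers stand for stronger inhibition and higher numbers for weaker inhibition:
- compound 1 `Cc1nc(N)c2c(-c3cccs3)cn([C@@H]3O[C@H](CO)[C@@H](O)[C@H]3O)c2n1`: > 20000 nM
- compound 2 `Cc1nc(N)c2c(-c3cc4ccccc4o3)cn([C@@H]3O[C@H](CO)[C@@H](O)[C@H]3O)c2n1`: 15700 nM

Compound 1 gives > 20000 nM, and this is a limit of this assay, not a number. Going by the values given here, compound 2 is thus the only compound with an actual number, 15700 nM, so no ranking beyond that one step can be drawn.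

The next compound is compound 3 `C#Cc1cn([C@@H]2O[C@H](CO)[C@@H](O)[C@H]2O)c2nc(C)nc(N)c12`, with ethynyl in place of 1-benzofuran-2-yl on an aromatic carbon. Among the compounds with values here, the one measured step at this place is an at least 1.2-fold lower number from compound 1 to compound 2 (0.10 log units; that floor lies within the scatter). That step exchanges one aromatic ring group for another, whereas ethynyl has no ring, so it gives only weak guidance here. With compound 2 already at 15700 nM, a moderate move toward a lower number is expected, with wide uncertainty and no firm support from the measured step.

The estimated change is a 3.9-fold lower number from compound 2 to compound 3 (0.59 log units; beyond the scatter). For compound 3 the estimated value is 4000 nM, with an expected range of 300 nM to 20000 nM.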

Compound 3, half-maximal inhibitory concentration: > 20000 nM
Compound 3: no number, only a limit; the forecaster's own chance of this, stated with the estimate: 25%; at least 5.0-fold (0.69 log units) between middle value and limit.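

In this assay compound 3 gives > 20000 nM, which is a limit and not a number. Ethynyl in place of 1-benzofuran-2-yl gives an at least 1.2-fold higher number from compound 2 to compound 3 (0.10 log units; that floor lies within the scatter), so this position now carries a group with no ring as well as two aromatic ring groups, and the floor of this step does not establish a real loss against compound 2, which remains the only compound of the three with an actual number. The step from compound 1 to compound 3 cannot be read, and the two compounds cannot be placed relative to each other: the limit of > 20000 nM in this assay, at which 2 of the 3 values shown sit.

As far as these compounds go, how far compound 1 and compound 3 lie past the limit stays open, and so does any order between thiophen-2-yl and ethynyl at this aromatic carbon. Also open, from the compounds shown here alone, is how an amine, a carboxylic acid or a longer chain at the same place would read in this assay, and whether any of these would give a number clearly lower than that of compound 2.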